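Little Cell Toxicity Across a Small Halogen Series

The source may report more compounds than this note shows. Statements on the series, on what has been measured and on what is new or still open speak of the compounds shown alone.

Values so far in an ADME assay on L6 cells (Rattus norvegicus) for cytotoxicity, read by resazurin assay, with a stated time of 72 h (on this read-out higher numbers stand for weaker inhibition and lower numbers for stronger inhibition), are:
- compound 1 `OC(c1ccc(Cl)cc1)(c1cccnc1)c1ccccc1F` gives > 100000 nM (a limit)
- compound 2 `OC(c1ccc(Cl)cc1)(c1cccnc1)c1ccc(F)cc1F` gives 70200 nM (a number)
- compound 3 `OC(c1ccc(Cl)cc1)(c1cccnc1)c1ccc(Br)cc1F` gives 79200 nM (a number)

Compound 1 gives > 100000 nM as a limit of the assay, not a number. Its standing is simply the limit of > 100000 nM in this assay, at which 1 of the 3 values shown sits, and no more.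

Compound 4 `OC(c1ccc(Cl)cc1)(c1cccnc1)c1ccsc1` differs by thiophen-3-yl in place of 2-fluorophenyl on a saturated chain carbon bound to two aromatic carbons and an oxygen on a saturated carbon and keeps the rest of the core of compound 1.

For the measured compounds named here, no measured step swaps a whole ring, so the nearest guides are single halogen changes. They show an at least 1.4-fold lower number from compound 1 to compound 2 (0.15 log units; that floor lies within the scatter) and an at least 1.2-fold lower number from compound 1 to compound 3 (0.10 log units; that floor lies within the scatter) while a 1.1-fold higher number from compound 2 to compound 3 (0.05 log units; within the scatter) also stays small.

On that basis, the expected change in this assay is an at least 1.2-fold lower number from compound 1 to compound 4 (0.09 log units; that floor lies within the scatter) and any shift beyond the scatter is not expected.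

Compound 4 is estimated at 80000 nM with an expected range of 40000 nM to 130000 nM in this measurement.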

Compound 4, half-maximal inhibitory concentration: > 100000 nM
Compound 4 was reported as a limit (the forecaster's own chance of this, stated with the estimate: 40%); at least 1.2-fold (0.09 log units) between middle value and limit.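

Compound 1 and compound 4 are both reported only as limits in this assay, not as numbers, and the step between them cannot be read. As far as these compounds go, whether thiophen-3-yl in place of 2-fluorophenyl changes the read-out at all remains open.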